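Swapping methoxy for chloro on a carboxylated ring

The compounds below may be only part of what the source reports. "The series", "measured", "known", "first", "only" and "open" are said of these compounds alone.

Measured in an ADME assay on microsomes from liver (Rattus norvegicus) for metabolic stability, read by LC-MS, with a stated time of 1 h, at 37 degrees C, tested at 4 uM; a higher number here means that more of the compound is left, a lower number that less of the compound is left:
- compound 1 `Cn1sc2cc(OCc3cccc(-c4ccc(Cl)c(C(=O)O)c4)c3)ccc2c1=O`: 84%
- compound 2 `O=C1c2ccc(OCc3cccc(-c4ccccc4)c3)cc2CN1C1CCCC1`: 38%
- compound 3 `COc1ccc(C(=O)O)cc1-c1cccc(COc2ccc3c(c2)CN(C2CCCC2)C3=O)c1`: 30%

Compound 3 gives 30%, which lies within the scatter of compound 2 and well short of compound 1. The next compound, compound 4 `O=C(O)c1ccc(Cl)c(-c2cccc(COc3ccc4c(c3)CN(C3CCCC3)C4=O)c2)c1`, has chloro in place of methoxy on an aromatic carbon. This turns the 5-carboxy-2-methoxyphenyl group into 5-carboxy-2-chlorophenyl.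

Among the compounds with values here, no measured step makes this exact swap. The closest is a number 8 percentage points lower from compound 2 to compound 3 (within the scatter), where 5-carboxy-2-methoxyphenyl replaces phenyl, and that step stays within the scatter. Compound 1 also carries chloro and carboxy groups and gives 84%, but its core and the arrangement of those groups differ from compound 4, so it offers only a weak hint upward. The expected change is therefore small, a number 8 percentage points higher from compound 3 to compound 4 (within the scatter), with no clear shift beyond the scatter anticipated. For compound 4 the estimated value is 38%, with an expected range from 20% to 58%.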

Compound 4, percent of the compound remaining: 15%
The estimate for compound 4 lay 23 percentage points above the measured number; measured number below the stated range.
By their numbers in this assay, from the lowest: compound 4; then compounds 3 and 2 (each within the scatter of the next); then compound 1.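

In this assay this position proves sensitive to which group it carries: on the carbon ortho to a large group and para to a carboxy group, chloro in place of methoxy gives a number 15 percentage points lower from compound 3 to compound 4 (beyond the scatter). Against the plain phenyl, the 5-carboxy-2-chlorophenyl group gives a number 23 percentage points lower from compound 2 to compound 4 (beyond the scatter), whereas the 5-carboxy-2-methoxyphenyl group gave only a number 8 percentage points lower from compound 2 to compound 3 (within the scatter), so on this shared core the chloro form is the one that separates clearly from phenyl. Nothing available here accounts for the drop.

Open, as far as these compounds go, is whether the drop is specific to chloro, as a fluoro or methyl group at this carbon could show, or whether it needs the carboxy group, as 2-chlorophenyl could show. Also open, from the compounds shown here alone, is how the same swap would behave on the core of compound 1, which gives 84%.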